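A few compounds are considered here, and "the series" means these few. Any claim that something is new, unique, unknown or untested is made for them only; others in the source may bear on it.

In a functional assay (blood) for inhibition, with Homo sapiens as the target (a higher number here means a weaker inhibitor, a lower number a stronger inhibitor), compound 1 (`COc1ccc2nc(COc3ccc4c(c3)c(SC(C)(C)C)c(CC(C)(C)C(=O)O)n4Cc3ccc(Cl)cc3)sc2c1`) gives 670 nM, while compound 2 (`CC(C)(C)Sc1c(CC(C)(C)C(=O)O)n(Cc2ccc(Cl)cc2)c2ccc(OCc3nc4ccccc4o3)cc12`) gives 2500 nM, the higher number and so the weaker inhibitor of this pair. Compound 3 (`CC(COc1ccc2c(c1)c(SC(C)(C)C)c(CC(C)(C)C(=O)O)n2Cc1ccc(Cl)cc1)c1ccccn1`) differs from compound 2 in one group: 1-(pyridin-2-yl)ethyl in place of 1,3-benzoxazol-2-yl on a saturated chain carbon bound to an oxygen on an aromatic ring. Here 1-(pyridin-2-yl)ethyl takes the place of 1,3-benzoxazol-2-yl on a saturated chain carbon bound to an oxygen on an aromatic ring. For the measured compounds named here, only one measured step involves this place: a 3.7-fold higher number from compound 1 to compound 2 (0.57 log units; beyond the scatter). Going by the values given here, that modest step shows that a swap here can move the number in this assay, but no measured compound carries 1-(pyridin-2-yl)ethyl, so the data give no firm direction. A step of similar size either way is therefore plausible, with little net change the likeliest outcome. The expected step is a 1.2-fold higher number from compound 2 to compound 3 (0.08 log units; within the scatter). Compound 3 is estimated at 3000 nM, with an expected range from 800 nM to 10000 nM.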

Compound 3, half-maximal inhibitory concentration: 270 nM
For compound 3 the middle estimate is 11-fold (1.05 log units) above the measured one; measured number below the stated range.
By their numbers in this assay, from the lowest: compound 3; then compound 1; then compound 2.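

Replacing 1,3-benzoxazol-2-yl with 1-(pyridin-2-yl)ethyl on a saturated chain carbon bound to an oxygen on an aromatic ring gives a 9.3-fold lower number from compound 2 to compound 3 (0.97 log units; beyond the scatter) in this assay and shows that this place can shift the number further than the earlier pair did. The same group also gives a 2.5-fold lower number from compound 1 to compound 3 (0.39 log units; beyond the scatter) so neither 1,3-benzoxazol-2-yl nor 6-methoxy-1,3-benzothiazol-2-yl is needed for a low number, and among these compounds a single six-membered aromatic ring with one hetero atom does best. Nothing available here explains why this change lowers the number.

Still open, as far as these compounds go, is whether the pyridine ring or the branched ethyl link accounts for the drop. A plain phenyl group on the same ethyl link, or a pyridin-2-yl group without the branch, would help separate the two.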